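From compound 1 to compound 4: the linker change

The source may hold more compounds than are shown below. What is called first, only, known or untested is meant among the compounds shown, and "the series" means these compounds.

Measured compounds:
compound 1 `Cc1ccccc1Oc1ccc(N2C[C@@H](C(F)(F)F)C[C@H]2CC(=O)O)cc1` gives 35 nM
compound 2 `Cc1ccccc1Oc1ccc(N2CCC[C@H]2CC(=O)O)cc1` gives 4400 nM
compound 3 `Cc1cccc(Oc2ccc(N3CCC[C@H]3CC(=O)O)cc2)c1` gives "not determined" (no result reported)

All numbers come from an assay on HEK293 cells for binding affinity to Free fatty acid receptor 1 (Homo sapiens), read by scintillation counting and radioligand binding, with a stated time of 1 h; a higher number here means a weaker inhibitor, a lower number a stronger inhibitor. Compound 1 stands at the lowest of the two numbers available; compound 2 is the only other entry with a number, and the step of a 130-fold higher number from compound 1 to compound 2 (2.10 log units; beyond the scatter) is large, resting on hydrogen in place of trifluoromethyl on a saturated ring carbon. Compound 3 carries no result, so it adds nothing to the comparison.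

Compound 4 `Cc1ccccc1Cc1ccc(N2C[C@@H](C(F)(F)F)C[C@H]2CC(=O)O)cc1` differs from compound 1 in one place: 2-methylbenzyl in place of 2-methylphenoxy on an aromatic carbon. Going by the values given here, no measured step concerns this part of the molecule; the single step available changes the saturated ring and leaves the 2-methylphenoxy untouched, so it gives no direct guide. The trifluoromethyl and the acid of compound 1 are kept in compound 4. Among the compounds with values here, with no precedent for the link, only a modest shift, possibly toward a higher number, is expected: compound 4 is estimated at 80 nM, within 20 nM to 400 nM, which means an expected step of a 2.3-fold higher number from compound 1 to compound 4 (0.36 log units; beyond the scatter).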

Compound 4, inhibition constant: 73 nM
Estimate against measurement, compound 4: 1.1-fold (0.04 log units) above; the range from low to high includes it.
By their numbers in this assay, from the lowest: compound 1; then compound 4; then compound 2.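

In this assay, going by these compounds alone, the change at this aromatic carbon gives the first reading on the link to the 2-methylphenyl ring, and 2-methylbenzyl in place of 2-methylphenoxy carries a real but modest cost (a 2.1-fold higher number from compound 1 to compound 4 (0.32 log units; beyond the scatter)), beyond the scatter yet much smaller than the large loss on removing trifluoromethyl (a 130-fold higher number from compound 1 to compound 2 (2.10 log units; beyond the scatter)). The ether oxygen is therefore not required for compound 4 to keep a number close to that of compound 1, although compound 1 remains the lower of the two. No available evidence accounts for the size of this step.

Open, on these data alone, is whether a secondary amine, a sulfur atom or a carbonyl as the link would give a different result. Also open, as far as these compounds go, is whether the same step would appear in a compound lacking trifluoromethyl, such as compound 2.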